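The source may hold more compounds than are shown below. What is called first, only, known or untested is meant among the compounds shown, and "the series" means these compounds.

Measured in an ADME assay on Vero cells (Chlorocebus sabaeus) for cytotoxicity; on this read-out lower numbers stand for higher toxicity in this test and higher numbers for lower toxicity in this test:
compound 1 `NC(=O)c1cccc2[nH]c(-c3ccccn3)nc12` — 224 uM
compound 2 `NC(=O)c1cccc2[nH]c(-c3cccnc3)nc12` — 77.7 uM
compound 3 `O=C(Nc1ccccc1F)c1cccc2[nH]c(-c3cccnc3)nc12` — 54.7 uM

Compound 2 holds the second highest of these three numbers; compound 3 sits within the scatter of it, while compound 1 stands further off, the gap being a 2.9-fold lower number from compound 1 to compound 2 (0.46 log units; beyond the scatter). Compound 4 `Cc1csc(NC(=O)c2cccc3[nH]c(-c4cccnc4)nc23)n1` differs from compound 2 by 4-methyl-1,3-thiazol-2-yl in place of hydrogen on an amide-type nitrogen. Going by the values given here, the one measured step at the same nitrogen is a 1.4-fold lower number from compound 2 to compound 3 (0.15 log units; within the scatter), which stays within the scatter. The step from compound 1 to compound 2 concerns another site and offers little guidance here. On this basis no step beyond the scatter is expected in this assay from compound 2 to compound 4, at most a slight drift towards lower numbers. The expected value for compound 4 is 55 uM, with a range from 25 uM to 120 uM, which would mean a step of a 1.4-fold lower number from compound 2 to compound 4 (0.15 log units; within the scatter).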

Compound 4, half-maximal toxic concentration: 111 uM
Compound 4: the middle estimate sits 2.0-fold (0.30 log units) below what was measured; the range from low to high includes it.
By their numbers in this assay, from the lowest: compounds 3, 2, 4 and 1 (each within the scatter of the next, the first and the last beyond it).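

At the amide-type nitrogen, 4-methyl-1,3-thiazol-2-yl gives a 1.4-fold higher number from compound 2 to compound 4 (0.15 log units; within the scatter) in this assay, so this larger substituent, like 2-fluorophenyl, leaves the read-out within the scatter of the unsubstituted amide. Going by these compounds alone, the two substituents are nevertheless distinguishable from each other: exchanging 2-fluorophenyl for 4-methyl-1,3-thiazol-2-yl gives a 2.0-fold higher number from compound 3 to compound 4 (0.31 log units; beyond the scatter), the first step beyond the scatter at this nitrogen. No available measurement explains this difference.

On these data alone, whether the methyl group on the thiazole contributes to this gap remains open. Also open, as far as these compounds go, is whether an aminoethyl or carboxymethyl group on this nitrogen would move the value beyond the scatter of compound 2.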